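A few compounds are considered here, and "the series" means these few. Any claim that something is new, unique, unknown or untested is made for them only; others in the source may bear on it.

Three compounds have entries in a functional assay on CWR22R cells (Homo sapiens) for antiproliferative activity, read by CCK-8 assay, with a stated time of 6 days; on this read-out higher numbers stand for weaker inhibition and lower numbers for stronger inhibition. Compound 1 `N#Cc1ccc(N2CCc3cc(-c4cncnc4)ccc32)cc1C(F)(F)F` has no number there, its entry reading "not determined" (no result reported). Compound 2 `CCN(c1ccc(C#N)c(Cl)c1)c1cc(-c2ccnn2C)ccc1C` gives 4330 nM and compound 3 `CCN(c1ccc(C#N)c(C(F)(F)F)c1)c1cc(-n2ccnc2)ccc1C` gives 16300 nM, so compound 2 holds the lower of the two numbers, with a gap beyond the scatter. The step followed here leads from compound 2 to compound 4 `CCN(c1ccc(C#N)c(Cl)c1)c1cc(-c2cccnc2)ccc1C`, with pyridin-3-yl in place of 1-methyl-1H-pyrazol-5-yl on an aromatic carbon. Going by the values given here, no measured pair shows such an exchange, so no change beyond the scatter is expected in this assay. The expected change is a 1.2-fold higher number from compound 2 to compound 4 (0.06 log units; within the scatter). For compound 4 the estimated value is 5000 nM, with an expected range of 1800 nM to 14000 nM.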

Compound 4, half-maximal inhibitory concentration: 2000 nM
Compound 4: middle estimate off by 2.5-fold (0.40 log units), on the high side; the measured number falls inside the stated range.
By their numbers in this assay, from the lowest: compound 4; then compound 2; then compound 3.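

In this assay, going by these compounds alone, pyridin-3-yl in place of 1-methyl-1H-pyrazol-5-yl gives a 2.2-fold lower number from compound 2 to compound 4 (0.34 log units; beyond the scatter), the first step in this set between compounds that differ in one place. Within the data shown here, it shows that the ring on this aromatic carbon, meta to a large group and para to a methyl group, changes the number, though only this one pair speaks to that. Nothing at hand explains the drop. Still open, as far as these compounds go, is whether a pyridin-3-yl carrying an amine, or a morpholine ring on this carbon, would lower the number further, and whether the exchange holds with trifluoromethyl in place of chlorine.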